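The compounds below may be only part of what the source reports. "The series", "measured", "known", "first", "only" and "open" are said of these compounds alone.

In an in vivo ADME assay on the whole organism (plasma) for pharmacokinetics, with Rattus norvegicus as the target, at a dose of 50 mg/kg by the oral route (a higher number here means more compound in the circulation at the dose given, a lower number less compound in the circulation), compound 1 (`Cc1cc(C)c(NC(=O)c2sccc2S(=O)(=O)Nc2onc(C)c2Cl)c(C)c1`) gives 81600 nM and stands highest of the three numbers in hand. Compound 2 (`Cc1cc(C)c(N(C)C)c(C)c1NC(=O)c1sccc1S(=O)(=O)Nc1onc(C)c1Cl`) stands at 6620 nM and compound 3 (`Cc1cc(C)c(NS(C)(=O)=O)c(C)c1NC(=O)c1sccc1S(=O)(=O)Nc1onc(C)c1Cl`) at 5250 nM on the same read-out. Dimethylamino in place of hydrogen on an aromatic carbon gives a 12-fold lower number from compound 1 to compound 2 (1.09 log units; beyond the scatter) and methanesulfonamido in place of hydrogen on an aromatic carbon gives a 16-fold lower number from compound 1 to compound 3 (1.19 log units; beyond the scatter) so both steps are large. The two added groups do not separate (a 1.3-fold lower number from compound 2 to compound 3 (0.10 log units; within the scatter)).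

Compound 4 (`CCCS(=O)(=O)c1cc(C)cc(C)c1NC(=O)c1sccc1S(=O)(=O)Nc1onc(C)c1Cl`) has not yet been measured. It carries propylsulfonyl in place of methyl on an aromatic carbon, ortho to a large group and meta to two methyl groups. Neither measured step replaces a methyl, so both bear on this change only loosely. Going by the values given here, still, both substitutions on the aromatic ring of compound 1 lowered the number, and no measured compound goes against this. A lower number is therefore expected for compound 4 in this assay on the evidence of compound 2 at 6620 nM and compound 3 at 5250 nM with the size of the step less certain. The expected step is a 10-fold lower number from compound 1 to compound 4 (1.01 log units; beyond the scatter) with a wide margin. For compound 4 the estimate is 8000 nM with an expected range of 2000 nM to 30000 nM on this read-out.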

Compound 4, maximal plasma concentration: 5450 nM
Beside the measured number, compound 4's estimate is 1.5-fold (0.17 log units) above it, within the range that was stated.
By their numbers in this assay, from the lowest: compounds 3, 4 and 2 (each within the scatter of the next); then compound 1.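

Going by these compounds alone, replacing a methyl that stands ortho to a large group and meta to two methyl groups with propylsulfonyl gives a 15-fold lower number from compound 1 to compound 4 (1.18 log units; beyond the scatter) in this assay, so this position is also sensitive to change, a point the earlier steps could not address because both replaced a hydrogen elsewhere on the ring. The change brings in six heavy atoms and two hydrogen-bond acceptors but no hydrogen-bond donor and no net charge, and all three changes to the aromatic ring of compound 1 now lower the number, with no shown compound going against this. No measurement shown explains the size of this step or ties it to any feature of the propylsulfonyl group.

The compounds shown do not separate the contribution of the sulfonyl from that of the propyl chain, and methylsulfonyl, a plain propyl chain or a hydrogen at this position would address that. Also open, going by these compounds, is whether a small group such as fluorine or methoxy at this position would keep the number close to that of compound 1, which gives 81600 nM.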